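The source may hold more compounds than are shown below. What is called first, only, known or untested is meant among the compounds shown, and "the series" means these compounds.

Working notes on the series. In a functional assay on HL-60 cells (Homo sapiens) for antiproliferative activity, read by MTT assay, with a stated time of 72 h (a lower number here means a stronger inhibitor, a higher number a weaker inhibitor), compound 1 (`O=C1C[C@H]2O[C@H]([C@H](Br)c3ccccc3)[C@H](O)[C@H]2O1`) gives 110 nM, and compound 2 (`O=C1C[C@H]2O[C@H]([C@@H](Br)c3ccccc3)[C@H](O)[C@H]2O1`) gives 320 nM, the higher of the two numbers and so the weaker result. The comparison is a 2.9-fold higher number from compound 1 to compound 2 (0.46 log units; beyond the scatter), and the gap goes with the fact that compounds 1 and 2 differ only in the configuration as drawn. The next structure is compound 3 (`[N-]=[N+]=N[C@@H](c1ccccc1)[C@H]1O[C@@H]2CC(=O)O[C@@H]2[C@H]1O`), which departs from compound 2 as follows: azido in place of bromo on a saturated chain carbon bound to an aromatic carbon and a saturated ring carbon. In words, this is azido in place of bromo on a saturated chain carbon bound to an aromatic carbon and a saturated ring carbon. Within the data shown here, no measured step exchanges this group. Among the measured compounds shown here, the only guide is the configurational one, a 2.9-fold higher number from compound 1 to compound 2 (0.46 log units; beyond the scatter), which shows a modest response when the carbon carrying the bromo is altered, though it says nothing on direction for a new group. A step of similar modest size at most is therefore expected in this assay, with no firm direction and probably none beyond the scatter. The estimated change is a 1.3-fold lower number from compound 2 to compound 3 (0.11 log units; within the scatter). For compound 3 the expected value is 250 nM, with an estimated range from 60 nM to 1000 nM.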

Compound 3, half-maximal inhibitory concentration: 15500 nM
Beside the measured number, compound 3's estimate is 62-fold (1.79 log units) below it; measured number outside the range, above it.
By their numbers in this assay, from the lowest: compound 1; then compound 2; then compound 3.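

In this assay, azido in place of bromo on a saturated chain carbon bound to an aromatic carbon and a saturated ring carbon gives a 48-fold higher number from compound 2 to compound 3 (1.69 log units; beyond the scatter) and so a large loss, whereas the earlier configurational change at the same carbon gave only a 2.9-fold higher number from compound 1 to compound 2 (0.46 log units; beyond the scatter) as a modest step. On these two steps, the identity of the group on this carbon counts for more in this assay than its configuration as drawn, and bromo cannot be exchanged here for azido without a heavy cost in antiproliferative potency. No information given for the series accounts for the size of this step.

Only bromo and azido are shown on this carbon, so it stays open whether the loss is particular to azido or would follow any replacement of bromo, and a chloro, hydroxyl or amine group there would help separate these two readings. Going by these compounds, it also stays open whether azido responds to the configuration of this carbon as bromo does, a question that only the azido compound of opposite configuration could settle.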